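Swapping the bicyclic ether in a histamine H2 ligand series

A few compounds are considered here, and "the series" means these few. Any claim that something is new, unique, unknown or untested is made for them only; others in the source may bear on it.

Compound 1 `Cc1ncc2nccn2c1-c1ccc(Oc2nccc3occc23)cc1C(F)(F)F` and compound 2 `FC(F)(F)c1cc(Oc2nccc3occc23)ccc1-c1cccc2nccn12` were both tested in an assay on cells for displacement of a labelled ligand from histamine H2 receptor (Homo sapiens), read by scintillation counting, with a stated time of 90 min; on this read-out lower numbers stand for stronger inhibition and higher numbers for weaker inhibition. In this assay compound 1 gives 8200 nM, and compound 2 gives 6700 nM. For the measured compounds named here, the only step between them, a 1.2-fold lower number from compound 1 to compound 2 (0.09 log units; within the scatter), exchanges the ring system carried on the aromatic carbon and stays within the scatter. Compound 2 thus holds the lowest of the two numbers shown, but the gap to compound 1 is within the scatter, so no order between the two can be read from it.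

Compound 3 `FC(F)(F)c1cc(Oc2nccc3ccsc23)ccc1-c1cccc2nccn12` has not yet been measured. It differs from compound 2 by a group of 9 heavy atoms (7 carbon, 1 nitrogen, 1 sulfur; one five-membered aromatic ring with 1 hetero atom, one six-membered aromatic ring with 1 hetero atom) in place of a group of 9 heavy atoms (7 carbon, 1 nitrogen, 1 oxygen; one five-membered aromatic ring with 1 hetero atom, one six-membered aromatic ring with 1 hetero atom), on an oxygen on an aromatic ring. Going by the values given here, no measured step touches this part of the molecule: the single step recorded, from compound 1 to compound 2, alters the other end of the shared core and is itself within the scatter. The data offer no ground for a shift beyond the scatter in either direction. The step expected here, a 1.1-fold lower number from compound 2 to compound 3 (0.05 log units; within the scatter), therefore stays within the scatter. For compound 3 in this assay the estimate is 6000 nM, with a range from 2500 nM to 15000 nM.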

Compound 3, inhibition constant: 2500 nM
Compound 3: the middle estimate sits 2.4-fold (0.38 log units) above what was measured, and the stated range covers the measured number.
By their numbers in this assay, from the lowest: compound 3; then compounds 2 and 1 (each within the scatter of the next).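

For the compounds shown here, at the position on an oxygen on an aromatic ring, this assay gives the first step beyond the scatter, a 2.7-fold lower number from compound 2 to compound 3 (0.43 log units; beyond the scatter), and this step is modest. Going by these compounds alone, the group that leaves and the group that enters have the same ring sizes, the same heavy-atom count and the same hydrogen-bond donor and acceptor counts, and neither carries a net charge, so the groups differ by sulfur in place of oxygen; the one earlier step, a 1.2-fold lower number from compound 1 to compound 2 (0.09 log units; within the scatter), changed the other end of the molecule and stayed within the scatter. The data shown offer no measurement that explains why this exchange lowers the number.

Within the data shown here, the exchange is seen only with the end group of compound 2 and compound 3, so it remains open whether the same sulfur-for-oxygen change would lower the number on the core of compound 1 by a similar amount. Going by these compounds, it also remains open how the number would respond if a plain phenyl ring or a group carrying a primary amine stood on that same oxygen on an aromatic ring.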